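The source may hold more compounds than are shown below. What is called first, only, known or untested is meant among the compounds shown, and "the series" means these compounds.

Measured so far in an ADME assay on microsomes from liver (Homo sapiens) for metabolic stability; on this read-out higher numbers stand for a longer-lived compound and lower numbers for a shorter-lived compound:
- compound 1 `CC(C)C(c1ccc(-c2ccc3cccc(F)c3c2)[nH]c1=O)C1C(=O)NC(=O)N1C`: 0.375 h
- compound 2 `CC(C)[C@@H](c1ccc(-c2ccc3cccc(F)c3c2)[nH]c1=O)[C@@H]1OC(=O)NC1=O`: > 3 h
- compound 3 `CC(C)/C(=C1\NC(=O)OC1=O)c1ccc(-c2ccc3cccc(F)c3c2)[nH]c1=O`: > 3 h

Within the data shown here, compound 1 is the only member of the series with a plain number in this assay. Compound 2 sits at a limit of the assay rather than a number. Compound 3 likewise reports only a limit. Compound 1 therefore stands alone at the short-lived end, with both other compounds at the limit of > 3 h in this assay, at which 2 of the 3 values shown sit.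

Compound 4 `CC(C)C(/C=C1\SC(=O)NC1=O)c1ccc(-c2ccc3cccc(F)c3c2)[nH]c1=O` has not been run in this assay. It differs from compound 1 by a group of 8 heavy atoms (4 carbon, 1 nitrogen, 2 oxygen, 1 sulfur; one five-membered non-aromatic ring with 2 hetero atoms) in place of a group of 8 heavy atoms (4 carbon, 2 nitrogen, 2 oxygen; one five-membered non-aromatic ring with 2 hetero atoms), on a saturated chain carbon bound to an aromatic carbon and a saturated chain carbon. Among the measured compounds shown here, no measured pair changes one place only, so the size of this step is untested. Given that compound 2 and compound 3 each reach the limit while compound 1 does not, an upward step beyond the scatter is expected, estimated as a 4.0-fold higher number from compound 1 to compound 4 (0.60 log units; beyond the scatter). Compound 4 is thus expected at 1.5 h, range 0.5 h to 3 h.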

Compound 4, half-life: > 3 h
Compound 4: no number, only a limit; the forecaster's own chance of this, stated with the estimate: 30%; middle value at least 2.0-fold (0.30 log units) from the limit.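

At this saturated chain carbon, replacing 3-methyl-2,5-dioxoimidazolidin-4-yl with the sulfur-containing ring gives a single-place step in this assay: an at least 8.0-fold higher number from compound 1 to compound 4 (0.90 log units; beyond the scatter). Compound 4 reports only a limit, so the step has a lower bound and no upper one. Compound 4 joins the group at the long-lived end: the limit of > 3 h in this assay, at which 3 of the 4 values shown sit.

On these data alone, how far compound 4 lies past that limit stays open, as does the contribution of the ring sulfur alone. Also open, as far as these compounds go, is how a carboxylic acid or an amine would behave at this carbon.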